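Notes on the step from compound 2 to compound 4

The source may hold more compounds than are shown below. What is called first, only, known or untested is meant among the compounds shown, and "the series" means these compounds.

Compound 2 `COc1cc(OC)c(/C=C/S(=O)(=O)Cc2ccc(OC)c(N)c2)c(OC)c1` gives the lowest number of the three measured in a functional assay on K562 cells (Homo sapiens) for cytotoxicity, read by trypan blue exclusion, with a stated time of 96 h (on this read-out higher numbers stand for weaker inhibition and lower numbers for stronger inhibition), at 2.5 nM. Compound 1 `COc1ccc(CS(=O)(=O)/C=C/c2c(OC)cccc2OC)cc1N` gives 50 nM in this assay, and compound 3 `COc1cc(OC)c(/C=C/S(=O)(=O)Cc2cc(N)ccc2OC)c(OC)c1` gives 7500 nM. Both measured steps are large: a 20-fold lower number from compound 1 to compound 2 (1.30 log units; beyond the scatter) with methoxy in place of hydrogen on an aromatic carbon, and a 3000-fold higher number from compound 2 to compound 3 (3.48 log units; beyond the scatter) with 5-amino-2-methoxyphenyl in place of 3-amino-4-methoxyphenyl on a saturated chain carbon bound to a sulfonyl sulfur. Compound 4 `COc1cc(OC)c(/C=C/S(=O)(=O)Cc2ccc(OC)c(NC(C(=O)O)c3ccc(Br)cc3)c2)c(OC)c1` differs from compound 2 at another place: (4-bromophenyl)(carboxy)methyl in place of hydrogen on a nitrogen on an aromatic ring. Within the data shown here, neither measured step alters anything on that nitrogen, so no step bears directly on this change; the two steps show only that a single change in this set can move this assay a long way in either direction. Among the measured compounds shown here, with no direct precedent, the expectation is a loss of moderate size rather than none beyond the scatter, held with wide uncertainty. Compound 4 is estimated at 50 nM, with a range of 5 nM to 500 nM, which means an expected step of a 20-fold higher number from compound 2 to compound 4 (1.30 log units; beyond the scatter).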

Compound 4, half-maximal inhibitory concentration: 200 nM
Compound 4: the middle estimate sits 4.0-fold (0.60 log units) below what was measured, within the range that was stated.
By their numbers in this assay, from the lowest: compound 2; then compound 1; then compound 4; then compound 3.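

In this assay, among these compounds, the nitrogen on an aromatic ring proves sensitive to substitution: (4-bromophenyl)(carboxy)methyl in place of hydrogen gives an 80-fold higher number from compound 2 to compound 4 (1.90 log units; beyond the scatter), a large step at a place the earlier compounds left untouched. The free amino group is nonetheless not required for a measurable number, as compound 4 still gives 200 nM with 11 heavy atoms entering on that nitrogen. No data shown account for the size of this step.

The entering group brings a carboxylic acid and a 4-bromophenyl ring together, so the compounds shown do not tell which part carries the step. A methyl ester in place of the carboxylic acid, a plain phenyl in place of 4-bromophenyl, or a simple methyl on the nitrogen would each bear on that question.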